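Estimating Compound 4 From a Single Measured Neighbour

The source may report more compounds than this note shows. Statements on the series, on what has been measured and on what is new or still open speak of the compounds shown alone.

Measured so far, all in a functional assay on SW1990 cells (Homo sapiens) for inhibition, read by MTT assay, with a stated time of 72 h; a lower number here means a stronger inhibitor, a higher number a weaker inhibitor
- Compound 1 `COc1cc(-c2c(-c3ccc4cc[nH]c4c3)c(=O)c2=O)cc(OC)c1OC` gives "not determined" (no result reported)
- Compound 2 `COc1cc(-c2c(-c3ccc4[nH]ccc4c3)c(=O)c2=O)cc(OC)c1OC` gives "not determined" (no result reported)
- Compound 3 `COc1ccc(-c2c(-c3cc(OC)c(OC)c(OC)c3)c(=O)c2=O)cc1N` gives 1770 nM

Within the data shown here, compound 1 has no number to stand on, and the same gap applies to compound 2, so only one compound offers a real measurement. The still unmeasured compound 4 `COc1ccc(-c2c(-c3cc(OC)c(OC)c(OC)c3)c(=O)c2=O)cc1F` is reached by one structural change 3-fluoro-4-methoxyphenyl in place of 1H-indol-6-yl on an aromatic carbon and this places 3-fluoro-4-methoxyphenyl in place of 1H-indol-6-yl on an aromatic carbon. A group holding a five-membered and a six-membered aromatic ring thus gives way to a group with a single six-membered ring.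

Without a value for compound 1, the size and direction of this step cannot be read from the data. The only anchor in this assay is compound 3 at 1770 nM in this test. A result near that figure is expected, with no gap beyond the usual scatter, though a slightly weaker result would not surprise.

Compound 4 is estimated at 2500 nM (expected range 700 nM to 9000 nM).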

Compound 4, half-maximal inhibitory concentration: 27 nM
The estimate for compound 4 lay 93-fold (1.97 log units) above the measured number, outside the stated range (below it).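

In this assay, replacing amino with fluoro on an aromatic carbon, with the rest of the molecule unchanged, gives a 66-fold lower number from compound 3 to compound 4 (1.82 log units; beyond the scatter). Among these compounds, this is the first pair of measured compounds that differ in one place, and it shows that this position is highly sensitive: exchanging one small group for another moves the number far beyond the usual scatter, and fluoro is clearly the better of these two groups here. No measurement at hand bears on why the step is so large.

As far as these compounds go, whether other groups at this place, such as chloro, hydroxyl or a nitrile, would match fluoro remains open. Also open, from the compounds shown here alone, is whether the same exchange would have a similar effect alongside 1H-indol-6-yl, since compound 1, which carries that group, offers no number for comparison.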